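Ethylsulfanyl in place of methylsulfanyl at the shared core

A few compounds are considered here, and "the series" means these few. Any claim that something is new, unique, unknown or untested is made for them only; others in the source may bear on it.

Compound 1 `CSc1nc(N)c2ncn([C@H]3C[C@H](OP(=O)(O)O)[C@@H](COP(=O)(O)O)O3)c2n1` shows the higher of the two numbers in a functional assay on cell membranes for antagonist activity at P2Y purinoceptor 1 (Meleagris gallopavo); on this read-out higher numbers stand for weaker inhibition and lower numbers for stronger inhibition: compound 1 gives 1890 nM, while compound 2 `CNc1nc(SC)nc2c1ncn2[C@H]1C[C@H](OP(=O)(O)O)[C@@H](COP(=O)(O)O)O1` gives 362 nM. Within the data shown here, the only measured step, a 5.2-fold lower number from compound 1 to compound 2 (0.72 log units; beyond the scatter), changes a different place than the one now in question. Compound 3 `CCSc1nc(N)c2ncn([C@H]3C[C@H](OP(=O)(O)O)[C@@H](COP(=O)(O)O)O3)c2n1` differs from compound 1 by methyl in place of hydrogen on a saturated chain carbon bound to a sulfur. Among the measured compounds shown here, with no step at that place to draw on, a change within the scatter is expected, so a 1.3-fold lower number from compound 1 to compound 3 (0.10 log units; within the scatter) is the estimate, and compound 3 is expected to give 1500 nM in this assay, between 450 nM and 5000 nM.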

Compound 3, half-maximal inhibitory concentration: 4590 nM
Compound 3: the middle estimate sits 3.1-fold (0.49 log units) below what was measured; low and high end bracket the measured number.
By their numbers in this assay, from the lowest: compound 2; then compound 1; then compound 3.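

In this assay, going from methylsulfanyl to ethylsulfanyl on the shared core is not a silent change: the step is a 2.4-fold higher number from compound 1 to compound 3 (0.39 log units; beyond the scatter), so this place responds to one added methyl. The change runs towards weaker inhibition, which the earlier step, at a different place, could not show. Nothing available explains this shift. Going by these compounds, whether a propyl chain or a benzyl group on the sulfur would weaken inhibition further stays open, as does whether methyl on a nitrogen on an aromatic ring would lower the number with ethylsulfanyl in place.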